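The source may report more compounds than this note shows. Statements on the series, on what has been measured and on what is new or still open speak of the compounds shown alone.

Of the compounds shown here, two have been tested so far in a functional assay on HeLa cells (Homo sapiens) for antiproliferative activity, read by MTT assay, with a stated time of 72 h; on this read-out higher numbers stand for weaker inhibition and lower numbers for stronger inhibition: compound 1 `O=C1C[C@@H]2O[C@@H](Cc3ccccc3)[C@@H](O)[C@@H]2O1` gives 1210 nM, and compound 2 `O=C1C[C@@H]2O[C@H]3[C@H](c4ccccc4)c4ccccc4CO[C@H]3[C@@H]2O1` gives 6560 nM. Compound 2 therefore holds the higher of the two numbers, making it the weaker inhibitor of the pair by a gap beyond the scatter. Compound 3 `O=C1C[C@H]2O[C@@H]3[C@@H](c4ccccc4)c4ccccc4CO[C@@H]3[C@H]2O1` still awaits measurement. It departs from compound 2 only in its three-dimensional arrangement: the two compounds have the same atoms and bonds and differ only in configuration as drawn: 5 of 5 stereo elements differ (all stereocentres are inverted: mirror images); a stereocentre at a saturated ring carbon is drawn S in compound 2 and R in compound 3; a stereocentre at a saturated ring carbon is drawn S in compound 2 and R in compound 3; a stereocentre at a saturated ring carbon is drawn R in compound 2 and S in compound 3; a stereocentre at a saturated ring carbon is drawn R in compound 2 and S in compound 3. The two have the same atoms and bonds, and all stereocentres are inverted, so they are mirror images. Among the measured compounds shown here, no measured pair here shows what such an inversion does, which leaves the size of the step uncertain. A moderate move toward stronger inhibition is expected, though the opposite direction cannot be ruled out, and the estimated change is a 2.2-fold lower number from compound 2 to compound 3 (0.34 log units; beyond the scatter). In this assay, compound 3 is estimated at 3000 nM, with an expected range of 500 nM to 12000 nM.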

Compound 3, half-maximal inhibitory concentration: > 100000 nM
Compound 3: only a limit was reported; the forecaster's own chance of this, stated with the estimate: 3%; middle value at least 33-fold (1.52 log units) from the limit.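

In this assay, the mirror-image change gives an at least 15-fold higher number from compound 2 to compound 3 (1.18 log units; beyond the scatter), so the spatial arrangement of this scaffold can by itself separate a compound with measurable inhibition from one without a measured potency. As far as these compounds go, compound 3 gives > 100000 nM, which is a limit of the assay and not a number, so the true size of the step stays unknown beyond what is printed. With nothing else altered, this large step can be traced to configuration alone: the fact that compounds 2 and 3 differ only in the configuration as drawn

Which of the stereocentres matter most stays open, as only the complete inversion appears here. Also open, from the compounds shown here alone, is whether an amine or a carboxylic acid added to the core of compound 2 would shift its value in this assay, and whether the same group would leave the gap between the mirror images intact.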